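The compounds below may be only part of what the source reports. "The series", "measured", "known", "first", "only" and "open" are said of these compounds alone.

Measured compounds:
- compound 1, `CCn1c(=O)n(C2OC(CO)[C@@H](O)[C@H]2O)c2nc(N)nc(O)c21`: 82% in a functional assay on the whole organism with Mus musculus as the target; a lower number here means a smaller maximal response, a higher number a larger maximal response
- compound 2, `C=CCn1c(=S)n([C@@H]2O[C@H](CO)[C@H]3OC(C)(C)O[C@H]32)c2nc(N)nc(O)c21`: compound 2 gives 9%
- compound 3, `C=CCn1c(=S)n(COCCO)c2nc(N)nc(O)c21`: compound 3 gives 7%

Of the three compounds measured in this assay, compound 1 stands highest. Compound 2 lies nearest to it, a number well beyond the usual scatter below it, and compound 3 lies furthest, again well beyond the scatter. Going by the values given here, both lower compounds differ from compound 1 in several places at once, so no single step between measured compounds can be read off.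

Compound 4, `CCOC(=O)Cn1c(=O)n(C2OC(CO)[C@@H](O)[C@H]2O)c2nc(N)nc(O)c21`, is not yet measured. It differs from compound 1 in one place: ethoxycarbonyl in place of methyl on a saturated chain carbon bound to an aromatic nitrogen. Among the compounds with values here, no measured pair shows this change, so the size of its effect rests on expectation alone. Given how much of the shared core stays the same, a moderate downward step is expected rather than a large one, though the range must stay wide. For compound 4 in this assay the expected value is 60%, between 20% and 90%. The expected step is a number 22 percentage points lower from compound 1 to compound 4 (beyond the scatter).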

Compound 4, largest response reached (reported as maximal response), in percent of the reference or control that the assay uses: 58%
The estimate for compound 4 lay 2 percentage points above the measured number, and the stated range covers the measured number.
By their numbers in this assay, from the lowest: compounds 3 and 2 (each within the scatter of the next); then compound 4; then compound 1.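

In this assay, going by these compounds alone, the exchange of methyl for ethoxycarbonyl on a saturated chain carbon bound to an aromatic nitrogen gives a number 24 percentage points lower from compound 1 to compound 4 (beyond the scatter), the first change at a single place that can be read. It shows that this position is sensitive to what it carries, yet the change does not abolish the response, since compound 4 still gives 58% with the rest of compound 1 unchanged. Nothing available bears on why the response falls with this change.

On these data alone, it remains open whether the step follows from the ester itself or simply from the longer substituent, which a plain propyl or butyl chain at the same place would help to separate. A carboxylic acid or an amide in place of the ester would show whether the ester function itself matters.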